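The compounds below may be only part of what the source reports. "The series", "measured", "known", "first", "only" and "open" are said of these compounds alone.

Measured compounds:
compound 1, `O=C(CCCCCCc1ccccc1)c1nc(Br)co1`, 3 nM in an assay on isolated protein for inhibition of Fatty-acid amide hydrolase 1 (Rattus norvegicus); a higher number here means a weaker inhibitor, a lower number a stronger inhibitor
compound 2, `O=C(CCCCCCc1ccccc1)c1nc(-c2ccncc2)co1`, 1.6 nM in this assay

Among the measured compounds shown here, compound 2 has the lower of the two numbers in this assay, but its only neighbour is compound 1, and the step of a 1.9-fold lower number from compound 1 to compound 2 (0.27 log units; within the scatter) lies within the scatter, so the two compounds cannot be told apart on these measurements. The next compound, compound 3, `COc1coc(C(=O)CCCCCCc2ccccc2)n1`, is not yet measured. It differs from compound 2 in one place: methoxy in place of pyridin-4-yl on an aromatic carbon. For the measured compounds named here, no measured step touches the same position with a comparable change; the one step on record, a 1.9-fold lower number from compound 1 to compound 2 (0.27 log units; within the scatter), shows that exchanging one group for another at that aromatic carbon left the number essentially unchanged. That step, however, placed a ring where a single atom had been, whereas here a ring is removed and a small group put in its place, so it offers only weak guidance. On this basis a modest rise in the number is expected, a 7.5-fold higher number from compound 2 to compound 3 (0.88 log units; beyond the scatter), with a wide margin either way. Compound 3 is therefore estimated at 12 nM in this assay, within a range from 3 nM to 50 nM.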

Compound 3, inhibition constant: 740 nM
Compound 3: the middle estimate sits 62-fold (1.79 log units) below what was measured, and the stated range ends below it.
By their numbers in this assay, from the lowest: compounds 2 and 1 (each within the scatter of the next); then compound 3.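

Until now, the aromatic carbon next to the ring nitrogen had carried only bromo and pyridin-4-yl, two groups that could not be told apart, so the position had seemed indifferent to what stood on it. Methoxy shows that it is not, giving a 460-fold higher number from compound 2 to compound 3 (2.67 log units; beyond the scatter) and a 250-fold higher number from compound 1 to compound 3 (2.39 log units; beyond the scatter) in this assay. Losing the ring cannot be the whole story either, since compound 1 has bromo and no ring at that carbon yet lies far from compound 3, and nothing available here bears on why methoxy differs so sharply from the other two groups.

The compounds shown leave open whether this large rise belongs to an oxygen joined directly to the ring or to methoxy as a whole, a question that a methyl or ethyl group or an amine at the same carbon would help to settle. They also leave open whether a phenyl or pyridin-3-yl ring there would stay level with compound 2, and whether the same gap would appear with a shorter or longer chain on the carbonyl.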